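This account rests on a few compounds, and the source may have more. Where it says the series, first, only, none or still open, it means among the compounds named here.

Measured compounds and their values:

Compound 1 `N#CC1=C(N)Oc2c(c3nc4ccccc4nc3c3ccccc23)C12C(=O)N(Cc1cnnn1-c1ccccc1Cl)c1ccccc12`; in an ADME assay on HUVEC cells (Homo sapiens) for antiproliferative activity, read by MTT assay, with a stated time of 48 h (on this read-out lower numbers stand for stronger inhibition and higher numbers for weaker inhibition), compound 1 gives > 50000 nM, which is a limit of the assay.
Compound 2 `N#CC1=C(N)Oc2c(c3nc4ccccc4nc3c3ccccc23)C12C(=O)N(Cc1cnnn1-c1cccc(Cl)c1)c1ccccc12`; in this assay compound 2 gives > 50000 nM, again a limit.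
Compound 3 `N#CC1=C(N)Oc2c(c3nc4ccccc4nc3c3ccccc23)C12C(=O)N(Cc1cnnn1-c1ccccc1Br)c1ccccc12`; in this assay compound 3 gives > 50000 nM, also a limit.

Compound 3 therefore stands at the limit of > 50000 nM in this assay, at which 3 of the 3 values shown sit, and no ordering among the three is readable. The measured steps within the set are a step that the two limits leave unreadable from compound 1 to compound 2, a step that the two limits leave unreadable from compound 1 to compound 3 and a step that the two limits leave unreadable from compound 2 to compound 3; each runs between two limits and its size cannot be read.

Compound 4 `COc1ccc(-n2nncc2CN2C(=O)C3(C(C#N)=C(N)Oc4c3c3nc5ccccc5nc3c3ccccc43)c3ccccc32)cc1` is not yet measured. It differs from compound 3 by 4-methoxyphenyl in place of 2-bromophenyl on an aromatic nitrogen, a change on the aromatic nitrogen of the five-membered ring with 3 nitrogen. The measured steps that bear on it are the three exchanges at this same position, and all three are unreadable, so they give no measurable direction for the new change.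

Nothing in the set points to a move off the limit, so compound 4 is expected to give 60000 nM in this assay, with a range of 25000 nM to 200000 nM. The step from compound 3 implied by this estimate, a step that the limit leaves unreadable from compound 3 to compound 4, is expected to stay within the scatter, most likely as another limit.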

Compound 4, half-maximal inhibitory concentration: > 50000 nM
Compound 4 was reported as a limit; the forecaster's own chance of this, stated with the estimate: 85%; the middle value does not contradict the limit.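

In this assay compound 4 gives > 50000 nM, which is a limit. Its steps from compound 1, compound 2 and compound 3 each run between two limits, and none can be read: the limit of > 50000 nM in this assay, at which 4 of the 4 values shown sit. The compounds shown leave open whether any other group on this aromatic nitrogen, or any change to the shared core, gives a measurable value.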